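This account rests on a few compounds, and the source may have more. Where it says the series, first, only, none or still open, it means among the compounds named here.

Measured compounds in an assay on isolated protein for inhibition of Ephrin type-A receptor 2 (Homo sapiens), read by thermal shift assay, tested at 10 uM; on this read-out higher numbers stand for stronger stabilisation of the target against heat and lower numbers for weaker stabilisation of the target: compound 1 `Cc1ccc(-n2nc(C(C)(C)C)cc2NC(=O)Nc2cc(C(F)(F)F)cc(C(F)(F)F)c2)cc1` gives 0.8 degrees C; compound 2 `Cc1ccc(-n2nc(C(C)(C)C)cc2NC(=O)Nc2cc(F)cc(F)c2)cc1` gives 1.9 degrees C; compound 3 `Cn1nc(C(C)(C)C)cc1NC(=O)Nc1cc(F)cc(F)c1` gives 0.4 degrees C.

Compound 3 stands lowest of the three numbers. Compound 1 lies within the scatter of it, whereas compound 2 lies beyond it, the step being a number 1.5 degrees C lower from compound 2 to compound 3 (beyond the scatter).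

Compound 4 `CC(C)(C)c1cc(NC(=O)Nc2cc(F)cc(F)c2)n(C(C)(C)C)n1` differs from compound 3 by tert-butyl in place of methyl on an aromatic nitrogen. Among the measured compounds shown here, the only measured step at this ring nitrogen is a number 1.5 degrees C lower from compound 2 to compound 3 (beyond the scatter), a modest loss when the 4-methylphenyl gave way to methyl. For the measured compounds named here, no compound with a tert-butyl at this nitrogen has been measured, so that step bears only indirectly. A small upward step, or none beyond the scatter, is expected: a number 0.40 degrees C higher from compound 3 to compound 4 (within the scatter). Compound 4 is therefore estimated at 0.8 degrees C, with a range of -0.3 degrees C to 2 degrees C.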

Compound 4, shift of the target's melting temperature: 0 degrees C
Compound 4: the middle estimate sits 0.80 degrees C above what was measured, and the stated range covers the measured number.
By their numbers in this assay, from the lowest: compounds 4, 3 and 1 (each within the scatter of the next); then compound 2.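

In this assay, tert-butyl on the aromatic nitrogen cannot be told apart from methyl: a number 0.40 degrees C lower from compound 3 to compound 4 (within the scatter). Against the 4-methylphenyl group the change gives a number 1.9 degrees C lower from compound 2 to compound 4 (beyond the scatter), so among the three groups shown at this nitrogen, only 4-methylphenyl stands beyond the scatter of the other two, and the larger tert-butyl does not recover the number of compound 2. Nothing available explains this difference. Open, on these data alone, is whether an unsubstituted phenyl, a benzyl or a pyridyl at this nitrogen would keep the number of compound 2.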